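The source may hold more compounds than are shown below. What is called first, only, known or untested is meant among the compounds shown, and "the series" means these compounds.

Measured so far:
Compound 1 `CCc1cc(Nc2nc(NCc3ccc(F)cc3)nc3ccccc23)n[nH]1` — 250 nM
Compound 2 `CCc1cc(Nc2nc(N[C@@H](C)c3ccc(F)cn3)nc3cccc(C)c23)n[nH]1` — 11 nM
Compound 3 `CCc1cc(Nc2nc(NCc3ccc(Cl)cc3OC)nc3ccccc23)n[nH]1` — 40 nM

These three compounds were tested in an assay on isolated protein for inhibition of G protein-coupled receptor kinase 6 (Homo sapiens), read by scintillation counting, radiometric assay and 33P incorporation, with a stated time of 80 min, in the presence of a further agent that is not named here; a higher number here means a weaker inhibitor, a lower number a stronger inhibitor. Compound 3 stands second of the three: compound 2 gives a lower number, compound 1 a higher one. For the measured compounds named here, the one single-point step measured, a 6.3-fold lower number from compound 1 to compound 3 (0.80 log units; beyond the scatter), concerns the aromatic ring on the side chain, not the core. Compound 4 `CCc1cc(Nc2nc(NCc3ccc(Cl)cc3OC)nc3cccc(C)c23)n[nH]1` differs from compound 3 by methyl in place of hydrogen on an aromatic carbon. Going by the values given here, no measured step covers this change; compound 2 carries the same methyl but also a different side chain, so its value cannot be attributed to the methyl alone. A small shift is expected, a 1.6-fold lower number from compound 3 to compound 4 (0.20 log units; within the scatter), and compound 4 is estimated at 25 nM, within 8 nM to 80 nM.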

Compound 4, half-maximal inhibitory concentration: 6 nM
Compound 4: the middle estimate sits 4.2-fold (0.62 log units) above what was measured; the whole stated range lies above it.
By their numbers in this assay, from the lowest: compounds 4 and 2 (each within the scatter of the next); then compound 3; then compound 1.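

In this assay, adding a single methyl on an aromatic carbon of the shared core gives a 6.7-fold lower number from compound 3 to compound 4 (0.82 log units; beyond the scatter) and so shows that this position responds to a change of one heavy atom. With that methyl in place, the side chain change gives a 1.8-fold lower number from compound 2 to compound 4 (0.26 log units; within the scatter) and leaves the 4-chloro-2-methoxybenzyl and 1-(5-fluoropyridin-2-yl)ethyl compounds indistinguishable here. Nothing available explains the effect of the methyl. On these data alone, it remains open whether a larger group at this carbon, such as trifluoromethyl or an amine, would act like methyl, and whether the methyl step would be similar with other side chains.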